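Methylcarbamoyl in place of 1,3-thiazol-2-yl: stability notes

The compounds below may be only part of what the source reports. "The series", "measured", "known", "first", "only" and "open" are said of these compounds alone.

Compound 1 (`C[C@H](O)[C@@H](CCc1ccc(C(F)(F)F)cc1)n1cnc2c(N)ncnc21`) gives > 0.5 h in an ADME assay on microsomes from liver (Homo sapiens) for metabolic stability, read by LC-MS, using NADPH, with stated times of 5 min and 30 min, at 37 degrees C (a lower number here means that the compound disappears faster, a higher number that the compound lasts longer), and this is a limit of the assay, not a number. Compound 2 (`C[C@H](O)[C@@H](CCc1cccc(-c2nccs2)c1)n1cnc2c(N)ncnc21`) gives > 0.5 h in this assay, again a limit. The two compounds therefore share one reading: the limit of > 0.5 h in this assay, at which 2 of the 2 values shown sit. On these data alone, neither can be ordered against the other, and the true half-life of compound 2 remains unknown.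

Compound 3 (`CNC(=O)c1cccc(CC[C@H]([C@H](C)O)n2cnc3c(N)ncnc32)c1`) carries methylcarbamoyl in place of 1,3-thiazol-2-yl on an aromatic carbon, meta to a large group: methylcarbamoyl in place of 1,3-thiazol-2-yl on an aromatic carbon. Among the measured compounds shown here, no measured step covers this change. The working expectation in this assay is therefore no shift beyond the scatter, with neither direction favoured. The estimated step is a step that the limit leaves unreadable from compound 2 to compound 3. A further report at the limit would be no surprise. For compound 3 the expected half-life is 0.6 h, with an estimated range of 0.35 h to 1.5 h.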

Compound 3, half-life: > 0.5 h
Compound 3: no number, only a limit; the forecaster's own chance of this, stated with the estimate: 65%; the middle value lies beyond the limit too.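

Among the compounds shown here, compound 3 gives > 0.5 h in this assay, again a limit, and no step from compound 2 to compound 3 can be read. The compounds shown leave open the true half-life of each and any order among them: the limit of > 0.5 h in this assay, at which 3 of the 3 values shown sit.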